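From 4-Nitrophenyl to 3,4,5-Trifluorophenyl on the Sulfonyl Sulfur

The source may hold more compounds than are shown below. What is called first, only, known or untested is meant among the compounds shown, and "the series" means these compounds.

Of the compounds shown here, two sharing a core have been tested in a functional assay on HepG2 cells (Homo sapiens) for antiproliferative activity, with a stated time of 72 h (on this read-out lower numbers stand for an effect already at smaller amounts and higher numbers for an effect only at larger amounts of compound), and neither has yet given an exact number. The result for compound 1 `COc1ccc(-c2c(I)c(=O)c3c(OC)cc(OC)cc3n2S(=O)(=O)c2ccc(OC)cc2)cc1` is > 17300 nM and that is a limit. The result for compound 2 `COc1ccc(-c2cc(=O)c3c(OC)cc(OC)cc3n2S(=O)(=O)c2ccc([N+](=O)[O-])cc2)cc1` is > 29300 nM and that too is a limit. Compound 3 `COc1ccc(-c2cc(=O)c3c(OC)cc(OC)cc3n2S(=O)(=O)c2cc(F)c(F)c(F)c2)cc1` differs from compound 2 in one place. The change 3,4,5-trifluorophenyl in place of 4-nitrophenyl on a sulfonyl sulfur is 3,4,5-trifluorophenyl in place of 4-nitrophenyl on a sulfonyl sulfur. Within the data shown here, no measured pair shows what such a swap does in this assay so no step beyond the usual scatter is expected, in either direction. With compound 2 at the limit of > 29300 nM in this assay, at which 1 of the 2 values shown sits, the expectation stays near that limit. The expected step is an at least 1.1-fold lower number from compound 2 to compound 3 (0.06 log units; that floor lies within the scatter) and this is only an estimate. For compound 3 the estimated value is 25000 nM with an expected range from 8000 nM to 60000 nM and the result may again be only a limit.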

Compound 3, half-maximal effective concentration: > 65500 nM
Compound 3: a limit, no number; the forecaster's own chance of this, stated with the estimate: 70%; middle value at least 2.6-fold (0.41 log units) from the limit.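

Compound 2 and compound 3 both gave limits and not exact numbers in this assay, and the step between them cannot be read. The compounds shown leave open whether 3,4,5-trifluorophenyl in place of 4-nitrophenyl on a sulfonyl sulfur changes the effect at all, and at what amount any of them would reach a half-maximal effect.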